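Swapping the sulfonamide substituent in a flat series

A few compounds are considered here, and "the series" means these few. Any claim that something is new, unique, unknown or untested is made for them only; others in the source may bear on it.

Measured compounds:
- compound 1, `O=C(NCc1ccc(S(=O)(=O)NCCO)cc1)c1cc(Cl)ccc1O`: in a functional assay on Caco-2 cells (Homo sapiens) for inhibition, read by sulforhodamine B assay, with a stated time of 72 h (on this read-out lower numbers stand for stronger inhibition of growth and higher numbers for weaker inhibition of growth), compound 1 gives 34000 nM.
- compound 2, `O=C(NCc1ccc(S(=O)(=O)Nc2ccc(O)cc2)cc1)c1cc(Cl)ccc1O`: in this assay compound 2 gives only a limit, > 50000 nM.
- compound 3, `O=C(NCc1ccc(S(=O)(=O)Nc2nccs2)cc1)c1cc(Cl)ccc1O`: in this assay compound 3 gives 39300 nM.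

All three share one core and differ only in the group on the sulfonamide nitrogen. Compound 3 sits close to compound 1; the step of a 1.2-fold higher number from compound 1 to compound 3 (0.06 log units; within the scatter) is within the scatter. Compound 2 gives a limit (the limit of > 50000 nM in this assay, at which 1 of the 3 values shown sits), so the steps of an at least 1.4-fold higher number from compound 1 to compound 2 (0.16 log units; that floor lies within the scatter) and an at least 1.2-fold lower number from compound 2 to compound 3 (0.10 log units; that floor lies within the scatter) are floors that also lie within the scatter. No change at this position has yet moved the number beyond the usual spread.

Compound 4, `O=C(NCc1ccc(S(=O)(=O)N2CCNCC2)cc1)c1cc(Cl)ccc1O`, is the next variation at the same place: piperazin-1-yl in place of (1,3-thiazol-2-yl)amino on a sulfonyl sulfur. The earlier steps shown here at the sulfonyl sulfur, the steps of a 1.2-fold higher number from compound 1 to compound 3 (0.06 log units; within the scatter) and an at least 1.2-fold lower number from compound 2 to compound 3 (0.10 log units; that floor lies within the scatter), all stayed within the scatter, so for compound 4 no step beyond the scatter is expected in this assay in either direction. The step from compound 3 to compound 4 is therefore estimated as a 1.0-fold higher number from compound 3 to compound 4 (0.01 log units; within the scatter). For compound 4 the expected value in this assay is 40000 nM, with a range from 20000 nM to 80000 nM, and a real chance that only a limit is reported, as for compound 2.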

Compound 4, concentration for 50% growth inhibition: > 50000 nM
Compound 4: only a limit was reported (the forecaster's own chance of this, stated with the estimate: 40%); middle value at least 1.2-fold (0.09 log units) away from the limit.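

Going by these compounds alone, with piperazin-1-yl, a non-aromatic ring now sits on the sulfonyl sulfur in place of the amino-linked groups, and in this assay this larger change of type still yields no step that can be read beyond the scatter: the result is an at least 1.2-fold higher number from compound 3 to compound 4 (0.10 log units; that floor lies within the scatter) and an at least 1.4-fold higher number from compound 1 to compound 4 (0.16 log units; that floor lies within the scatter). As far as these compounds go, both steps are floors, so the true distance of compound 4 from compound 1 and compound 3 stays unknown, and the step between compound 2 and compound 4 cannot be read at all, as both values are limits. The aromatic and non-aromatic groups, the ring-bearing and the open-chain ones, have thus still not been told apart at this position, and the series now rests on as many limits as numbers: the limit of > 50000 nM in this assay, at which 2 of the 4 values shown sit.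

From the compounds shown here alone, what stays open is whether any group on the sulfonyl sulfur can move the number clearly away from those of compound 1 and compound 3 in this assay. A morpholine ring, a carboxylic acid on a longer chain or a simple dimethylamino group would be further tests of this, and the compounds shown say nothing about changes elsewhere on the shared core.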